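This account rests on a few compounds, and the source may have more. Where it says the series, first, only, none or still open, it means among the compounds named here.

Measured in a functional assay on A549 cells (Homo sapiens) for antiproliferative activity, read by sulforhodamine B assay, with a stated time of 48 h; a higher number here means a weaker inhibitor, a lower number a stronger inhibitor:

- Compound 1 `COc1ccc(/C=C/C(=O)c2ccccc2-c2cc(OC)c(OC)c(OC)c2)cc1O`: 290 nM
- Compound 2 `COc1ccc(C(=O)/C=C/c2ccccc2-c2ccc(F)cc2)cc1`: 8200 nM
- Compound 3 `COc1ccc(C(=O)/C=C/c2ccccc2-c2ccc(F)nc2)cc1`: > 50000 nM

Compound 3 gives no true number, since it stands at the limit of > 50000 nM in this assay, at which 1 of the 3 values shown sits. Its real value is therefore unknown, and any comparison with it has an open end.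

The next compound is compound 4 `COc1ccc(C(=O)/C=C/c2ccccc2-c2ccc(F)nc2)cc1O`, which adds one group to compound 3: hydroxy in place of hydrogen on an aromatic carbon. For the measured compounds named here, no measured step changes this position. Going by the values given here, the one measured step, an at least 6.0-fold higher number from compound 2 to compound 3 (0.78 log units; beyond the scatter), swaps 4-fluorophenyl for 6-fluoropyridin-3-yl elsewhere in the molecule, so it shows only that compound 3 lost ground at that other site.

The closest hint comes from compound 1 at 290 nM, which also carries a hydroxy group ortho to a methoxy group, although the rest of its structure differs. On that slender basis, a lower number is expected in this assay, not a change within the scatter. The estimated change is an at least 8.3-fold lower number from compound 3 to compound 4 (0.92 log units; beyond the scatter). For compound 4 the expected value is 6000 nM, with an estimated range of 1000 nM to 40000 nM.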

Compound 4, half-maximal inhibitory concentration: 3200 nM
The estimate for compound 4 lay 1.9-fold (0.27 log units) above the measured number; the range from low to high includes it.
By their numbers in this assay, from the lowest: compound 1; then compound 4; then compound 2. At a limit, above all of these: compound 3.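

This position now has a direct reading: in this assay, hydroxy in place of hydrogen, ortho to a methoxy group, gives an at least 15-fold lower number from compound 3 to compound 4 (1.19 log units; beyond the scatter). Before this, compound 1 offered only a hint, as it differs from the others in more than one place, whereas the hydroxy group is the only difference in this pair. On these data alone, the true size of the step remains open-ended because compound 3 stands at a limit: the limit of > 50000 nM in this assay, at which 1 of the 4 values shown sits.

The compounds shown leave open whether another group on this carbon, such as an amine or a second methoxy group, would give a similar step or whether hydroxy is needed. They also leave open whether the same hydroxy group would lower the number for compound 2, which carries 4-fluorophenyl instead of 6-fluoropyridin-3-yl.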